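This account rests on a few compounds, and the source may have more. Where it says the series, first, only, none or still open, it means among the compounds named here.

Measured so far:
Compound 1 `O=C(N1CCCCC1)N1CC(c2nc(-c3cccc(Cl)c3)no2)C1` — 370 nM
Compound 2 `Cc1cccc(-c2noc(C3CN(C(=O)C4CCC(C(F)(F)F)CC4)C3)n2)c1` — 1000 nM

Compound 1 gives the lower of the two numbers in an assay on HEK293 cells for positive allosteric modulation of metabotropic glutamate receptor 5 (Homo sapiens), read by FLIPR; on this read-out lower numbers stand for an effect already at smaller amounts and higher numbers for an effect only at larger amounts of compound; compound 2 sits at a higher number, a gap that lies beyond the usual scatter of this assay. Compound 3 `O=C([C@H]1CC2CCC1C2)N1CC(c2nc(-c3cccc(Cl)c3)no2)C1` has not yet been measured. It keeps the shared core of compound 1 and changes one place: a group of 7 heavy atoms (7 carbon; 2 five-membered non-aromatic rings of carbon only) in place of a group of 6 heavy atoms (5 carbon, 1 nitrogen; one six-membered non-aromatic ring with 1 hetero atom), on a carbonyl carbon. Among the compounds with values here, no measured pair isolates this single change; compound 2 differs from compound 1 in more than one place and therefore shows only that its own number is higher. The expectation for compound 3 is a small shift toward a higher number, a 1.5-fold higher number from compound 1 to compound 3 (0.17 log units; within the scatter), or none beyond the scatter, because compound 2 gives 1000 nM as the only measured carbon-ring carbonyl substituent. Compound 3 is estimated at 550 nM, within 150 nM to 2000 nM.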

Compound 3, half-maximal effective concentration: 74 nM
For compound 3 the middle estimate is 7.4-fold (0.87 log units) above the measured one, outside the stated range (below it).
By their numbers in this assay, from the lowest: compound 3; then compound 1; then compound 2.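

With the rest of compound 1 held fixed, the position on the carbonyl carbon responds clearly in this assay: replacing piperidin-1-yl with the carbon-only group of two five-membered non-aromatic rings gives a 5.0-fold lower number from compound 1 to compound 3 (0.70 log units; beyond the scatter). The earlier compounds shown here offered no single-place comparison here; this step shows that the nitrogen-containing ring of piperidin-1-yl is not needed at this position to reach a lower number. The data shown offer no measurement that accounts for this step.

The compounds shown leave open whether the lower number follows from the loss of the ring nitrogen or from the two-ring carbon group itself, a question that a simple cyclohexyl group could address. They also leave open what the defined stereocentre contributes, since the opposite stereoisomer of this group does not appear among them.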